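The compounds below may be only part of what the source reports. "The series", "measured", "known", "first", "only" and "open" are said of these compounds alone.

Compound 1 `O=C(CO)N1CCC(c2[nH]nc(-c3ccc(Cl)cc3)c2-c2ccncc2)CC1` at 15.8 mL/min/kg
Compound 2 `CC(=O)N1CCC(c2[nH]nc(-c3ccc(Cl)cc3)c2-c2ccncn2)CC1` at 9.5 mL/min/kg

Both compounds were measured in an in vitro ADME assay on microsomes from liver (Homo sapiens) for metabolic stability; a lower number here means slower removal, a higher number faster removal of the compound. Compound 2 stands level with compound 1 within the scatter, so neither stands apart on these numbers. Compound 3 `CS(=O)(=O)N1CCC(c2[nH]nc(-c3ccc(Cl)cc3)c2-c2ccncn2)CC1` is not yet measured and differs from compound 2 by methylsulfonyl in place of acetyl on an amine nitrogen in a ring with methylsulfonyl in place of acetyl on an amine nitrogen in a ring. For the measured compounds named here, no measured step covers this change. In this assay the expected 1.1-fold higher number from compound 2 to compound 3 (0.02 log units; within the scatter) stays within the scatter, with no direction favoured. Estimated for compound 3 is 10 mL/min/kg with 5 mL/min/kg to 19 mL/min/kg as the expected range.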

Compound 3, clearance: 18.1 mL/min/kg
For compound 3 the middle estimate is 1.8-fold (0.26 log units) below the measured one, within the range that was stated.
By their numbers in this assay, from the lowest: compounds 2, 1 and 3 (each within the scatter of the next).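

In this assay, for the compounds shown here, the exchange of methylsulfonyl in place of acetyl on an amine nitrogen in a ring gives a 1.9-fold higher number from compound 2 to compound 3 (0.28 log units; within the scatter) and is the first single-place read at this position. On this core, the two groups therefore cannot be separated in this read-out. Nothing in hand explains the size of this step.

Open, going by these compounds, is whether a urea or a longer chain on the same nitrogen would also stay within the scatter of compound 2. Also open, on these data alone, is whether this exchange reads the same on the core of compound 1.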